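This account rests on a few compounds, and the source may have more. Where it says the series, first, only, none or still open, it means among the compounds named here.

Measured in a functional assay on HCT-116 cells (Homo sapiens) for antiproliferative activity, read by MTT assay, with a stated time of 72 h; a higher number here means a weaker inhibitor, a lower number a stronger inhibitor:
- compound 1 `C=C1CN/C(=N/c2ccccc2)S1`: > 100000 nM (a limit of the assay, not a number)
- compound 2 `COc1ccc(/C=C2\S/C(=N\c3ccc(Cl)cc3)N(C)C2=O)cc1`: 10400 nM
- compound 3 `COc1ccc(/C=C2/CN(C)/C(=N/c3ccc(F)cc3)S2)cc1`: 10000 nM

Only two of these three results are actual numbers. Compound 2 at 10400 nM and compound 3 at 10000 nM lie within the usual scatter of repeated measurements, so the two stand level in this assay and neither can be ranked ahead of the other.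

The next compound to be tested is compound 4 `COc1ccc(/C=C2\S/C(=N\c3c(C)cccc3C)N(C)C2=O)cc1`. It keeps the rest of compound 2 and carries 2,6-dimethylphenyl in place of 4-chlorophenyl on a double-bonded nitrogen.

For the measured compounds named here, no two measured compounds differ in just one place, so the data give no direct measure of what a swap like this does. The forecast therefore has to start from compound 2 at 10400 nM, and it carries wide uncertainty. A small move toward a weaker number is expected, not far beyond the scatter. The expected step is a 1.3-fold higher number from compound 2 to compound 4 (0.13 log units; within the scatter). For compound 4 the estimated value is 14000 nM, with an expected range from 5000 nM to 45000 nM.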

Compound 4, half-maximal inhibitory concentration: > 100000 nM
Compound 4: no number, only a limit; the forecaster's own chance of this, stated with the estimate: 15%; at least 7.1-fold (0.85 log units) between middle value and limit.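

For the compounds shown here, this is the first pair of compounds that differ in just one place, and in this assay putting 2,6-dimethylphenyl in place of 4-chlorophenyl on a double-bonded nitrogen gives an at least 9.6-fold higher number from compound 2 to compound 4 (0.98 log units; beyond the scatter). The position is therefore not indifferent to what it carries, even though both groups are a six-membered aromatic ring of carbon only, with no hydrogen-bond donors or acceptors and no net charge. Compound 4 gives > 100000 nM, which is a limit of the assay and not a number, so the step is only a lower bound and its full size cannot be read: the limit of > 100000 nM in this assay, at which 2 of the 4 values shown sit.

Going by these compounds alone, the single swap also changes two things at once, removing the chlorine and adding two methyl groups, and the data do not show which of these matters or whether both do. Going by these compounds, how 4-methylphenyl or a pyridine ring would behave on this nitrogen remains open, as does whether any group here could give a clearly lower number than compound 2 shows at 10400 nM.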